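The compounds below may be only part of what the source reports. "The series", "measured", "known", "first", "only" and "open" are said of these compounds alone.

Measured compounds: compound 1 `c1c[nH]c(-c2ccccc2OCC2=NCCN2)c1` gives 1 nM in a functional assay for activation of Alpha-1B adrenergic receptor (Homo sapiens), read by calcium flux; on this read-out lower numbers stand for an effect already at smaller amounts and higher numbers for an effect only at larger amounts of compound; compound 2 `c1ccc(-c2cc[nH]n2)c(OCC2=NCCN2)c1` gives 79.4 nM in this assay; compound 3 `c1ccc(-c2ccns2)c(OCC2=NCCN2)c1` gives 12.6 nM in this assay.

Compound 3 stands second highest of the three numbers, between compound 1 and compound 2. Compound 4 `c1ccc(-c2nccs2)c(OCC2=NCCN2)c1` differs from compound 3 in one place: 1,3-thiazol-2-yl in place of 1,2-thiazol-5-yl on an aromatic carbon. For the measured compounds named here, two measured steps bear on such a swap of one five-membered ring for another, a 13-fold higher number from compound 1 to compound 3 (1.10 log units; beyond the scatter) and a 6.3-fold lower number from compound 2 to compound 3 (0.80 log units; beyond the scatter), and both were beyond the scatter. Going by the values given here, no step between two rings of the same atoms joined differently has been measured, so the direction is uncertain. A step of modest size in this assay is expected, a 1.6-fold higher number from compound 3 to compound 4 (0.20 log units; within the scatter), and compound 4 is estimated at 20 nM, within a range from 5 nM to 80 nM.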

Compound 4, half-maximal effective concentration: 20 nM
Compound 4: middle estimate and measured number agree at the digits printed, within the range that was stated.
By their numbers in this assay, from the lowest: compound 1; then compounds 3 and 4 (each within the scatter of the next); then compound 2.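

In this assay, the change at this aromatic carbon to 1,3-thiazol-2-yl from 1,2-thiazol-5-yl, the same atoms joined differently, gives a 1.6-fold higher number from compound 3 to compound 4 (0.20 log units; within the scatter) and so stays within the scatter; this read-out does not separate these two rings. The new ring keeps the gaps to the other two rings beyond the scatter, with a 4.0-fold lower number from compound 2 to compound 4 (0.60 log units; beyond the scatter) and a 20-fold higher number from compound 1 to compound 4 (1.30 log units; beyond the scatter) as its steps. The compounds come with no evidence that would explain these differences. Still open, from the compounds shown here alone, is whether an amine or a methyl group on the 1,3-thiazol-2-yl ring would bring the number closer to that of compound 1, at 1 nM in this assay.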